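Replacing a bromophenyl with a benzimidazolylmethyl group

The source may hold more compounds than are shown below. What is called first, only, known or untested is meant among the compounds shown, and "the series" means these compounds.

Measured compounds:
compound 1 `CN(CCNCc1cn(-c2ccc(F)cc2)nn1)CCNc1ccnc2cc(Cl)ccc12`: 34000 nM
compound 2 `CN(CCNCc1cn(-c2ccc(Br)cc2)nn1)CCNc1ccnc2cc(Cl)ccc12`: 15000 nM

Compound 2 gives the lower of the two numbers in a functional assay on NCI-H460 cells (Homo sapiens) for antiproliferative activity, read by sulforhodamine B assay, with a stated time of 72 h (a higher number here means a weaker inhibitor, a lower number a stronger inhibitor), with compound 1 giving the only other one; the change a 2.3-fold lower number from compound 1 to compound 2 (0.36 log units; beyond the scatter) is modest but beyond the scatter.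

Compound 3 `CN(CCNCc1cn(Cc2nc3ccccc3[nH]2)nn1)CCNc1ccnc2cc(Cl)ccc12` differs from compound 2 by (1H-benzimidazol-2-yl)methyl in place of 4-bromophenyl on an aromatic nitrogen. Going by the values given here, the one measured step, a 2.3-fold lower number from compound 1 to compound 2 (0.36 log units; beyond the scatter), swaps one halogen for another on the phenyl ring and does not bear on the removal of that ring in favour of a (1H-benzimidazol-2-yl)methyl group. Among the compounds with values here, no measured pair informs the direction of this change, so the expectation rests on compound 2 alone. Compound 3 is therefore expected to lie near compound 2, with a wide range in either direction, at an estimated 18000 nM (range 4000 nM to 80000 nM), and the step of a 1.2-fold higher number from compound 2 to compound 3 (0.08 log units; within the scatter) is expected to be small.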

Compound 3, half-maximal inhibitory concentration: 120000 nM
The estimate for compound 3 lay 6.7-fold (0.82 log units) below the measured number, and the stated range ends below it.
By their numbers in this assay, from the lowest: compound 2; then compound 1; then compound 3.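

In this assay, (1H-benzimidazol-2-yl)methyl on the aromatic nitrogen in place of 4-bromophenyl gives an 8.0-fold higher number from compound 2 to compound 3 (0.90 log units; beyond the scatter), and in place of 4-fluorophenyl it gives a 3.5-fold higher number from compound 1 to compound 3 (0.55 log units; beyond the scatter). This position therefore tolerates more than a change of halogen can reveal: replacing the whole group moves the number upward from both halophenyl compounds, and the step from the bromo compound is the largest shown. Nothing measured here accounts for this rise.

The compounds shown leave open whether the rise goes with the methyl link to the aromatic nitrogen or with the benzimidazole itself, and a benzyl group would separate the two. As far as these compounds go, it also remains open how a phenyl ring carrying an amine or a carboxylic acid would compare with the halophenyl compounds.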